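A Methyl on the Hydroxyethyl Chain of Compound 3

The compounds below may be only part of what the source reports. "The series", "measured", "known", "first", "only" and "open" are said of these compounds alone.

Compound 1, `CCCn1cnc2ncnc(N)c21`, in an assay on CHO cells for displacement of a labelled ligand from adenosine receptor A1 (Homo sapiens) (a lower number here means a stronger inhibitor, a higher number a weaker inhibitor), sits at a limit of the assay, > 100000 nM.
Compound 2, `CC(C)n1cnc2ncnc(N)c21`, in this assay gives 20000 nM.
Compound 3, `Nc1ncnc2ncn(CCO)c12`, in this assay sits at a limit of the assay, > 100000 nM.

Compound 3 therefore stands at the weak edge of what has been measured: its value is a limit, not a number, and the limit of > 100000 nM in this assay, at which 2 of the 3 values shown sit, marks how common that outcome is here. Compound 4, `CC(O)Cn1cnc2ncnc(N)c21`, differs from compound 3 by methyl in place of hydrogen on a saturated chain carbon bound to an oxygen on a saturated carbon and a saturated chain carbon. Two of the measured steps speak to this change. The step of an at least 5.0-fold lower number from compound 1 to compound 2 (0.69 log units; beyond the scatter) shows that adding a branch to the chain on the aromatic nitrogen brought the number down into the measurable range. The step of an at least 5.0-fold higher number from compound 2 to compound 3 (0.69 log units; beyond the scatter) shows that the hydroxyethyl chain, unbranched, sent the number back to the limit, while the step that the two limits leave unreadable from compound 1 to compound 3 cannot be sized. Compound 4 keeps the hydroxyl and adds a branch, so a modest improvement over compound 3 is expected, with a real chance that only a limit is reported again. For compound 4 in this assay the estimate is 80000 nM, within 25000 nM to 300000 nM. The expected step is an at least 1.2-fold lower number from compound 3 to compound 4 (0.09 log units; that floor lies within the scatter).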

Compound 4, inhibition constant: > 100000 nM
Compound 4: no number, only a limit; the forecaster's own chance of this, stated with the estimate: 55%; middle value at least 1.2-fold (0.09 log units) from the limit.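

In this assay, methyl in place of hydrogen on the chain carbon bound to the oxygen did not bring the hydroxylated chain off the limit: compound 4, like compound 3, gives no number. For the compounds shown here, with 2-hydroxypropyl in place of isopropyl on the aromatic nitrogen, the record shows an at least 5.0-fold higher number from compound 2 to compound 4 (0.69 log units; beyond the scatter) and so the branched chain bearing a hydroxy group does not match the isopropyl of compound 2, which remains the only compound of the four with a number. The steps from compound 3 and from compound 1 to compound 4 cannot be read, since both ends of each are limits, and the limit now holds most of the series: the limit of > 100000 nM in this assay, at which 3 of the 4 values shown sit.

Going by these compounds, how far compound 1, compound 3 and compound 4 lie beyond that limit, and whether they differ from one another at all, stays open. Also open, on these data alone, is whether an amine or a carboxylic acid in place of the hydroxy group, or a longer chain on the aromatic nitrogen, would give a measurable number in this assay as the isopropyl of compound 2 does.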